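Amino in Place of Hydroxy on Two Related Cores

The source may report more compounds than this note shows. Statements on the series, on what has been measured and on what is new or still open speak of the compounds shown alone.

The measured compounds and their values in a functional assay on A549 cells (Homo sapiens) for antiproliferative activity, read by MTT assay, with a stated time of 48 h; on this read-out lower numbers stand for stronger inhibition and higher numbers for weaker inhibition:
- compound 1, `COc1ccc(C(=O)c2ccc(OC)c3c2OC(C)(C)C=C3)c(NC(=O)CO)c1`: 80 nM
- compound 2, `COc1ccc(C(=O)c2ccc(OC)c3c2OC(C)(C)C=C3)c(NC(=O)CN)c1`: 270 nM
- compound 3, `C=C(c1cc(OC)c(OC)c(OC)c1)c1ccc(OC)cc1NC(=O)CO`: 20 nM

Compounds 1 and 2 share one core and differ in a single place: amino in place of hydroxy on a saturated chain carbon bound to a carbonyl carbon. On this assay that change gave a 3.4-fold higher number from compound 1 to compound 2 (0.53 log units; beyond the scatter), so the amino analogue compound 2 is the weaker of the two.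

Compound 3 carries a different core; the difference between the cores of compound 1 and compound 3 is not broken down here. On this assay compound 3 gives the lowest number of the three measured compounds, with compound 1 standing above it and compound 2 further above.

Compound 4, `C=C(c1cc(OC)c(OC)c(OC)c1)c1ccc(OC)cc1NC(=O)CN`, has not yet been measured. It relates to compound 3 exactly as compound 2 relates to compound 1: amino in place of hydroxy on a saturated chain carbon bound to a carbonyl carbon. The place of the change is described in the same words in both pairs, so this is the same change made on a second core.

Going by the values given here, the only guide to what compound 4 will do is the single earlier instance of this change. Because that instance gave a 3.4-fold higher number from compound 1 to compound 2 (0.53 log units; beyond the scatter), compound 4 is expected to show a step of a 3.5-fold higher number from compound 3 to compound 4 (0.54 log units; beyond the scatter), a loss of similar size, though a single precedent on another core leaves the size uncertain. On that basis compound 4 is estimated at 70 nM, within a range from 30 nM to 160 nM.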

Compound 4, half-maximal inhibitory concentration: 40 nM
Compound 4: the middle estimate sits 1.8-fold (0.24 log units) above what was measured; the range from low to high includes it.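

In this assay, amino in place of hydroxy on a saturated chain carbon bound to a carbonyl carbon gave a 2.0-fold higher number from compound 3 to compound 4 (0.30 log units; within the scatter), so on this second core the change cannot be told apart from the ordinary spread of repeated measurements. Set beside the earlier instance, the two steps do not differ by more than that spread allows: the same change on two cores in this assay, a 3.4-fold higher number (0.53 log units; beyond the scatter) from compound 1 to compound 2 and a 2.0-fold higher number (0.30 log units; within the scatter) from compound 3 to compound 4, 1.7-fold (0.23 log units) apart, within the scatter of two such steps. The step lies beyond the scatter on one core and within it on the other, so these two pairs show that the change carries from one core to the other with no detectable difference in its size, but they do not show that it weakens activity on every core, nor do they fix how large its effect is in general.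

The compounds shown leave open whether other groups at this place, such as a dimethylamino group, a carboxylic acid or a longer chain ending in an amine, would behave alike on both cores. They also leave open whether the step between hydroxymethyl and aminomethyl would stay this small on a third core or in a different cell line.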